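The source may report more compounds than this note shows. Statements on the series, on what has been measured and on what is new or still open speak of the compounds shown alone.

Three compounds from this series share a core in which an amide joins a substituted aniline to a saturated nitrogen-containing ring that carries a benzyl group. Compound 3 `O=C(Nc1ccc(-c2ccncc2)cc1)C1CCCN(Cc2ccc(F)c(F)c2)C1` was tested in a functional assay on A-375 cells (Homo sapiens) for activation, with a stated time of 3 days (a higher number here means that more compound is needed for the effect, a lower number that less compound is needed), and gives 1180 nM. Of the two numbers recorded, compound 3 stands lowest; compound 1 `O=C(Nc1ccc(-c2cscn2)cc1)C1CCN(Cc2ccc(F)c(F)c2)C1` gives 8000 nM, and that gap lies beyond the usual scatter of the assay. Compound 2 `O=C(Nc1ccc(-c2cscn2)cc1)C1CCCN(Cc2cccc(C(F)(F)F)c2)C1` did not reach a number at all: its result is recorded only as a limit of the assay, > 20000 nM, as seen in the limit of > 20000 nM in this assay, at which 1 of the 3 values shown sits.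

Compound 4 `O=C(Nc1ccc(-c2cccs2)cc1)C1CCCN(Cc2ccc(F)c(F)c2)C1` differs from compound 3 in one place: thiophen-2-yl in place of pyridin-4-yl on an aromatic carbon. No measured pair among these three compounds isolates that change, since compound 1 and compound 2 each differ from compound 3 in more than one place. The size of the step must therefore be estimated. A modest move toward a higher number is expected from compound 3 to compound 4, a 2.5-fold higher number from compound 3 to compound 4 (0.41 log units; beyond the scatter), though a result within the scatter cannot be excluded. Compound 4 is expected to give 3000 nM in this assay, with a likely range from 800 nM to 12000 nM.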

Compound 4, half-maximal effective concentration: 530 nM
For compound 4 the middle estimate is 5.7-fold (0.75 log units) above the measured one; the measured number lies below the stated range.
By their numbers in this assay, from the lowest: compound 4; then compound 3; then compound 1. At a limit, above all of these: compound 2.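

In this assay, among these compounds, putting thiophen-2-yl in place of pyridin-4-yl on the aromatic carbon gives a 2.2-fold lower number from compound 3 to compound 4 (0.35 log units; beyond the scatter), the first comparison in this set that isolates a single change. It shows that the ring nitrogen of pyridin-4-yl is not needed at this position for activity in this range: a five-membered aromatic ring carrying sulfur serves at least as well as the six-membered ring carrying nitrogen, and less compound is needed for the effect. Nothing measured here explains why the number falls, as no available evidence bears on this step.

Among the compounds shown here, this is a single pair, so it cannot show whether the preference extends to other aromatic rings or to other parts of the core, and compound 1 and compound 2 each differ from compound 4 in more than one place, so no step to them can be read. Also open, on these data alone, is how this position would respond to a plain phenyl ring, which has no hetero atom, or to a non-aromatic group such as an amine or a carboxylic acid.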